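A few compounds are considered here, and "the series" means these few. Any claim that something is new, unique, unknown or untested is made for them only; others in the source may bear on it.

In a functional assay on the whole organism (strain Sprague-Dawley) for inhibition, with Rattus norvegicus as the target, with a stated time of 10 min (on this read-out lower numbers stand for an effect already at smaller amounts and higher numbers for an effect only at larger amounts of compound), compound 1 `CCCOc1ccccc1-c1ncc(C(=O)OCC)c(=O)[nH]1` gives 5 mg/kg and compound 2 `CCOC(=O)c1cnc(-c2ccccc2OC(C)CC)[nH]c1=O` gives 0.5 mg/kg, the lower of the two numbers. Among the compounds with values here, the only measured step is a 10-fold lower number from compound 1 to compound 2 (1.00 log units; beyond the scatter). It comes from a single added methyl on the chain carbon bound to the oxygen, and it lies beyond the scatter. Compound 3 `C=CCOc1ccccc1-c1ncc(C(=O)OCC)c(=O)[nH]1` has yet to be measured in this assay. Its difference from compound 2 is allyl in place of sec-butyl on an oxygen on an aromatic ring. The allyl chain has no such methyl, so compound 3 looks closer to compound 1, at 5 mg/kg, than to compound 2, although the double bond has not been tested here. A move towards a higher number is therefore expected, with an estimated size of a 6.0-fold higher number from compound 2 to compound 3 (0.78 log units; beyond the scatter). For compound 3 the estimate is 3 mg/kg, with an expected range from 0.8 mg/kg to 10 mg/kg.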

Compound 3, dose for 50% inhibition: 0.5 mg/kg
Beside the measured number, compound 3's estimate is 6.0-fold (0.78 log units) above it; measured number outside the range, below it.
By their numbers in this assay, from the lowest: compounds 2 and 3 (each within the scatter of the next); then compound 1.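

In this assay the branch methyl of compound 2 proves not to be the only way to reach a low number at this oxygen: vinyl in place of ethyl on the chain carbon bound to it gives a clear change (a 10-fold lower number from compound 1 to compound 3 (1.00 log units; beyond the scatter)). Allyl in place of sec-butyl then leaves the result unmoved (no change at the digits printed from compound 2 to compound 3 (within the scatter)), so among these three compounds an unbranched chain with a double bond and a branched saturated chain read alike, and only compound 1 stands apart. Nothing measured here explains why these two different changes at the same place match.

From the compounds shown here alone, it remains open whether a branch methyl and a double bond together on the chain would change the number further. A propargyl group, with its triple bond, or a cyclopropylmethyl group on the same oxygen would test how specific the double bond is.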